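This account rests on a few compounds, and the source may have more. Where it says the series, first, only, none or still open, it means among the compounds named here.

Measured so far:
- compound 1 `CCC(C)n1ncn(-c2ccc(N3CCN(c4ccc(OC[C@@H]5CO[C@@](CN(C)C)(c6ccc(Cl)cc6Cl)O5)cc4)CC3)cc2)c1=O`: 1400 nM
- compound 2 `CCC(C)n1ncn(-c2ccc(N3CCN(c4ccc(OC[C@@H]5CO[C@@](CN6CCNCC6)(c6ccc(Cl)cc6Cl)O5)cc4)CC3)cc2)c1=O`: 608 nM

In a functional assay on HUVEC cells (Homo sapiens), read by scintillation counting and thymidine incorporation, with a stated time of 24 h (a higher number here means a weaker inhibitor, a lower number a stronger inhibitor), compound 1 gives 1400 nM, the highest of the two numbers. For the measured compounds named here, compound 2 gives 608 nM and is the nearest; the only measured step is a 2.3-fold lower number from compound 1 to compound 2 (0.36 log units; beyond the scatter), a modest gain that lies beyond the scatter.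

Compound 3 `CCC(C)n1ncn(-c2ccc(N3CCN(c4ccc(OC[C@@H]5CO[C@@](Cn6c(C)cnc6C)(c6ccc(Cl)cc6Cl)O5)cc4)CC3)cc2)c1=O` differs from compound 1 by 2,5-dimethyl-1H-imidazol-1-yl in place of dimethylamino on a saturated chain carbon bound to a saturated ring carbon. Going by the values given here, the one step that bears on this is the exchange of the same dimethylamino group, at the same place, for piperazin-1-yl, a 2.3-fold lower number from compound 1 to compound 2 (0.36 log units; beyond the scatter). Among the compounds with values here, the change to compound 3 again removes dimethylamino from that saturated chain carbon and puts a larger, ring-containing group there, so a step of similar size toward a lower number is expected, with no second precedent to sharpen it.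

Compound 3 is therefore expected near 700 nM. The range expected for compound 3 runs from 300 nM to 1600 nM. The expected step this implies is a 2.0-fold lower number from compound 1 to compound 3 (0.30 log units; within the scatter).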

Compound 3, half-maximal inhibitory concentration: 765 nM
The estimate for compound 3 lay 1.1-fold (0.04 log units) below the measured number; low and high end bracket the measured number.
By their numbers in this assay, from the lowest: compounds 2, 3 and 1 (each within the scatter of the next, the first and the last beyond it).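

In this assay, the exchange of dimethylamino for 2,5-dimethyl-1H-imidazol-1-yl on a saturated chain carbon bound to a saturated ring carbon gives a 1.8-fold lower number from compound 1 to compound 3 (0.26 log units; within the scatter), so this aromatic ring-bearing group cannot be told apart from dimethylamino at this position. The exchange of piperazin-1-yl for the same group gives a 1.3-fold higher number from compound 2 to compound 3 (0.10 log units; within the scatter), so it cannot be told apart from piperazin-1-yl either, even though the two groups it replaces are separated by a 2.3-fold lower number from compound 1 to compound 2 (0.36 log units; beyond the scatter). The position therefore tolerates a non-basic-looking change of group type only in the sense that the numbers stay within the scatter of their neighbours, and no measurement shown here accounts for any of these numbers.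

The compounds shown leave open whether an unsubstituted 1H-imidazol-1-yl, a morpholin-4-yl or a carboxylic acid on that saturated chain carbon would move the number beyond the scatter from compound 1. Also open, going by these compounds, is whether a longer chain carrying 2,5-dimethyl-1H-imidazol-1-yl or piperazin-1-yl would keep compound 2 and compound 3 this close.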